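Bromo removed from the anilide: cytotoxicity outlook

The source may report more compounds than this note shows. Statements on the series, on what has been measured and on what is new or still open speak of the compounds shown alone.

Of the compounds shown here, three have so far been measured in an ADME assay on HEK293 cells (Homo sapiens) for cytotoxicity, read by reporter gene assay and resazurin assay, with a stated time of 48 h; a lower number here means that less compound is tolerated, a higher number that more compound is tolerated. Compound 1 `O=C(Nc1ccc(Sc2nc3ccccc3s2)cc1)c1cc(Br)cc(Br)c1O` gives 66000 nM. For compound 2 `COc1c(Br)cccc1C(=O)Nc1ccc(Sc2nc3ccccc3s2)c(Cl)c1` only a limit of the assay is recorded, > 100000 nM. Compound 3 `COc1ccc(Br)cc1C(=O)Nc1ccccc1` likewise reaches only a limit of the assay, > 100000 nM. Compound 2 thus stands at the upper edge of what this assay reports, alongside compound 3, while compound 1 carries a measured number; the standing of compound 2 is summarised by the limit of > 100000 nM in this assay, at which 2 of the 3 values shown sit. Among the compounds with values here, no pair of measured compounds differs in a single place, so no measured step is available for comparison.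

Compound 4 `COc1ccccc1C(=O)Nc1ccc(Sc2nc3ccccc3s2)c(Cl)c1` is not yet measured. It differs from compound 2 as follows: hydrogen in place of bromo on an aromatic carbon. The bromo leaves an aromatic carbon of a six-membered aromatic ring of carbon only, ortho to a methoxy group and meta to a large group, and hydrogen enters in its place.

Given (the limit of > 100000 nM in this assay, at which 2 of the 3 values shown sit), a step in this assay beyond the scatter in either direction is not expected, and a further limit report seems the most probable outcome. Compound 4 is estimated at 120000 nM, with a range from 50000 nM to 300000 nM. The step this expectation implies, a step that the limit leaves unreadable from compound 2 to compound 4, is expected to stay within the scatter.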

Compound 4, half-maximal cytotoxic concentration: > 100000 nM
Compound 4: no number, only a limit; the forecaster's own chance of this, stated with the estimate: 65%; the middle value does not contradict the limit.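

In this assay compound 2 and compound 4 both end at a limit of the assay, so no step can be read for hydrogen in place of bromo on an aromatic carbon. The standing of compound 2 remains: the limit of > 100000 nM in this assay, at which 3 of the 4 values shown sit. The compounds shown leave open whether this replacement changes tolerance at all.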